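The source may hold more compounds than are shown below. What is called first, only, known or untested is meant among the compounds shown, and "the series" means these compounds.

Compound 2 `CCOC(=O)c1cnc(N2CCN(Cc3ccc(F)cc3)CC2)nc1Oc1c(C)cc(-c2ccc(C#N)cc2)cc1C` is the starting point. In an ADME assay on MT4 cells (Homo sapiens) for cytotoxicity, read by MTT assay, with a stated time of 4 days (a lower number here means that less compound is tolerated, a higher number that more compound is tolerated), compound 2 gives only a limit, > 117000 nM, with no number beyond it. Compound 1 `CCOC(=O)c1cnc(N2CCN(Cc3ccccc3C#N)CC2)nc1Oc1c(C)cc(-c2ccc(C#N)cc2)cc1C` also sits at a limit in this assay, > 125000 nM. Going by the values given here, compound 3 `CCOC(=O)c1cnc(N2CCN(Cc3cccc(C(N)=O)c3)CC2)nc1Oc1c(C)cc(-c2ccc(C#N)cc2)cc1C` is the one compound with a read number in this assay, 14800 nM. Of the three, compound 2 therefore stands at the upper end of what was measured, together with compound 1.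

Compound 4 `CCOC(=O)c1cnc(N2CCN(Cc3ccc(S(C)(=O)=O)cc3)CC2)nc1Oc1c(C)cc(-c2ccc(C#N)cc2)cc1C` differs from compound 2 in one place: methylsulfonyl in place of fluoro on an aromatic carbon. Among the compounds with values here, no measured step exchanges fluoro for methylsulfonyl, so the closest guidance comes from changes to the same benzyl group. The step that the two limits leave unreadable from compound 1 to compound 2 cannot be read, because both ends are limits the limit of > 117000 nM in this assay, at which 1 of the 3 values shown sits (the limit of > 125000 nM in this assay, at which 1 of the 3 values shown sits). The steps of an at least 8.4-fold lower number from compound 1 to compound 3 (0.92 log units; beyond the scatter) and an at least 7.9-fold lower number from compound 2 to compound 3 (0.89 log units; beyond the scatter) are the only readable ones, and both move the number down when the benzyl substituent changes. On that basis a downward step is expected from compound 2 to compound 4, an at least 1.9-fold lower number from compound 2 to compound 4 (0.29 log units; that floor lies within the scatter), though it may well stay within the limit. Compound 4 is estimated in this assay at 60000 nM, in a range from 15000 nM to 130000 nM.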

Compound 4, half-maximal cytotoxic concentration: > 125000 nM
Compound 4 ended at the assay's limit (the forecaster's own chance of this, stated with the estimate: 50%); middle value at least 2.0-fold (0.31 log units) away from the limit.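

Compound 4 stands at a limit in this assay, > 125000 nM, which is not a read number. So methylsulfonyl on this aromatic carbon, para to a large group, is the first change at this position that brings in hydrogen-bond acceptors on a group of four heavy atoms in place of a single fluoro, and it still gives no read number; the only readable step is an at least 8.4-fold higher number from compound 3 to compound 4 (0.92 log units; beyond the scatter), which leaves compound 3 as the one exception among the four compounds, the other three all sitting at limits. The steps from compound 1 and from compound 2 to compound 4 cannot be read, and how these three compounds rank remains unknown, since each of them sits at a limit: the limit of > 125000 nM in this assay, at which 2 of the 4 values shown sit.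

The compounds shown leave open whether the read number of compound 3 belongs to the carbamoyl group itself or to where it sits, a question that 4-carbamoylphenyl or 3-(methylsulfonyl)phenyl would address. They also leave open whether an amine or a carboxylic acid on this aromatic carbon would bring the number down from the limit in this assay.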